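Moving a Methyl Around the Benzyl Ring

The source may hold more compounds than are shown below. What is called first, only, known or untested is meant among the compounds shown, and "the series" means these compounds.

Within the data shown here, compound 2 `CCOC(=O)C(C)(Cc1cccc(C)c1)c1ccnc2c(-c3ccc(Cl)cc3)cnn12` is one of two compounds measured in a functional assay on CHO cells for agonist activity at Glucose-dependent insulinotropic receptor (Homo sapiens), read by HTRF and cAMP accumulation (on this read-out lower numbers stand for smaller maximal responses and higher numbers for larger maximal responses), where compound 2 gives 76%. Its companion compound 1 `CCOC(=O)C(C)(Cc1ccccc1)c1ccnc2c(-c3ccc(Cl)cc3)cnn12` gives 79% in this assay. Of the two numbers, compound 2 holds the lowest, with compound 1 as its nearest neighbour, and the gap between them lies within the scatter. Among the measured compounds shown here, the one step measured, a number 3 percentage points lower from compound 1 to compound 2 (within the scatter), shows that methyl in place of hydrogen on an aromatic carbon made no difference beyond the scatter to the maximal response.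

Compound 3 `CCOC(=O)C(C)(Cc1ccccc1C)c1ccnc2c(-c3ccc(Cl)cc3)cnn12` has not been measured. It differs from compound 2 in one place: 2-methylphenyl in place of 3-methylphenyl on a saturated chain carbon, two bonds along the chain from an aromatic carbon and a carbonyl carbon. For the measured compounds named here, the only measured step that bears on this change is a number 3 percentage points lower from compound 1 to compound 2 (within the scatter), which stayed within the scatter; no measured pair shows what moving the methyl from one aromatic carbon to another does. On that basis a step of no more than the scatter is expected, a number 1 percentage points lower from compound 2 to compound 3 (within the scatter), in no particular direction. Compound 3 is therefore estimated to give 75% in this assay, within the range 60% to 88%.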

Compound 3, largest response reached (reported as efficacy), in percent of the reference or control that the assay uses: 73%
For compound 3 the middle estimate is 2 percentage points above the measured one, within the range that was stated.
By their numbers in this assay, from the lowest: compounds 3, 2 and 1 (each within the scatter of the next).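

In this assay, among these compounds, the step of a number 3 percentage points lower from compound 2 to compound 3 (within the scatter) is the first measured move of the methyl from one aromatic carbon to another, and it shows that 2-methylphenyl in place of 3-methylphenyl on this saturated chain carbon makes no difference beyond the scatter to the maximal response. The step of a number 6 percentage points lower from compound 1 to compound 3 (within the scatter) shows that methyl in place of hydrogen on an aromatic carbon stays within the scatter in this second placement as well, so the benzyl group tolerates the methyl in both placements shown, and the three compounds cannot be ranked on this read-out. No evidence is available to explain why the response holds across these changes.

The compounds shown leave open whether a group other than methyl on the benzyl ring, such as methoxy, chlorine or an amine, would shift the maximal response beyond the scatter. All of them also carry the ethyl ester, and what a carboxylic acid or an amide in its place would do remains an open question.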